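From Trifluoromethyl to Cyano on a Phenoxy Group

The compounds below may be only part of what the source reports. "The series", "measured", "known", "first", "only" and "open" are said of these compounds alone.

In a functional assay with Homo sapiens as the target (on this read-out higher numbers stand for weaker inhibition and lower numbers for stronger inhibition), compound 1 (`CC(C)[C@H](NC(=O)COc1cccc2ccccc12)C(=O)N[C@@H](CC(=O)O)C(=O)COC(=O)c1c(Cl)cccc1Cl`) gives 11500 nM. Among the compounds with values here, compound 2 (`CC(C)[C@H](NC(=O)COc1cccc2ccccc12)C(=O)N[C@@H](CC(=O)O)C(=O)COc1cccc(C(F)(F)F)c1`) gives 16600 nM, which places it within the usual scatter of compound 1, the only other measured compound. Compound 3 (`CC(C)[C@H](NC(=O)COc1cccc2ccccc12)C(=O)N[C@@H](CC(=O)O)C(=O)COc1ccc(C#N)cc1`) keeps the shared core but carries 4-cyanophenyl in place of 3-(trifluoromethyl)phenyl on an oxygen on a saturated carbon. Within the data shown here, only one measured step bears on this change. It is a 1.4-fold higher number from compound 1 to compound 2 (0.16 log units; within the scatter), made at the same oxygen when 3-(trifluoromethyl)phenyl replaced (2,6-dichlorophenyl)carbonyl, and it stayed within the scatter. One step is thin evidence, but it gives no reason to expect a large shift here. The expected change, a 1.1-fold lower number from compound 2 to compound 3 (0.04 log units; within the scatter), is therefore none beyond the scatter. Compound 3 is estimated at 15000 nM, with an expected range from 6000 nM to 35000 nM.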

Compound 3, half-maximal inhibitory concentration: 26700 nM
Compound 3: the middle estimate sits 1.8-fold (0.25 log units) below what was measured, and the stated range covers the measured number.
By their numbers in this assay, from the lowest: compounds 1, 2 and 3 (each within the scatter of the next, the first and the last beyond it).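

In this assay, 4-cyanophenyl in place of 3-(trifluoromethyl)phenyl gives a 1.6-fold higher number from compound 2 to compound 3 (0.21 log units; within the scatter) and so cannot be told apart from it, even with a different substituent and a hydrogen-bond acceptor counted in the new group. Within the data shown here, the comparison with the ester group is the first at this oxygen to clear the scatter: 4-cyanophenyl in place of (2,6-dichlorophenyl)carbonyl gives a 2.3-fold higher number from compound 1 to compound 3 (0.37 log units; beyond the scatter) and is a modest step, so the position responds only slightly across these three groups, while compound 2 stays within the scatter of both others. No measurement here explains these numbers.

The compounds shown leave open what a simple methyl on this oxygen, or an amine on the aromatic ring, would do. They also leave open whether any group at this oxygen could produce a larger step.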